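This account rests on a few compounds, and the source may have more. Where it says the series, first, only, none or still open, it means among the compounds named here.

Measured so far:
Compound 1, `O=C(Nc1c(C(O)(C(F)(F)F)C(F)(F)F)ccc2ccccc12)C1CC1`, in an assay on LtK cells with ATP-sensitive inward rectifier potassium channel 11 (Homo sapiens) as the target (on this read-out higher numbers stand for an effect only at larger amounts of compound and lower numbers for an effect already at smaller amounts), gives 751 nM.
Compound 2, `O=C(NCCCCCCCl)Nc1c(C(O)(C(F)(F)F)C(F)(F)F)ccc2ccccc12`, in this assay gives 4840 nM.

Among the compounds with values here, compound 2 stands at the highest of the two numbers recorded, and the only step that connects it to another measured compound is a 6.4-fold higher number from compound 1 to compound 2 (0.81 log units; beyond the scatter).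

Compound 3, `O=C(Nc1c(C(O)(C(F)(F)F)C(F)(F)F)ccc2ccccc12)c1ccccc1`, has not been measured in this assay. It differs from compound 2 in one place: phenyl in place of (6-chlorohexyl)amino on a carbonyl carbon. The change removes the urea-type linkage of compound 2 and returns to a carbon substituent directly on the carbonyl, as in compound 1, where that substituent was cyclopropyl rather than phenyl.

Within the data shown here, the only measured step that bears on this change is a 6.4-fold higher number from compound 1 to compound 2 (0.81 log units; beyond the scatter), which runs in the opposite direction: exchanging the cyclopropyl of compound 1 for the (6-chlorohexyl)amino of compound 2 raised the number beyond the scatter. Among the measured compounds shown here, compound 3 reverses that type of change, though with a phenyl rather than a cyclopropyl, so no measured pair reports the exact outcome. Compound 3 is therefore expected to show a lower number than compound 2, a step of roughly a 4.8-fold lower number from compound 2 to compound 3 (0.68 log units; beyond the scatter), placing it near compound 1. Compound 3 is estimated at 1000 nM, with a range from 300 nM to 3500 nM.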

Compound 3, half-maximal effective concentration: 44 nM
Estimate against measurement, compound 3: 23-fold (1.36 log units) above; measured number outside the range, below it.
By their numbers in this assay, from the lowest: compound 3; then compound 1; then compound 2.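

Read in this assay, putting phenyl in place of (6-chlorohexyl)amino on a carbonyl carbon gives a 110-fold lower number from compound 2 to compound 3 (2.04 log units; beyond the scatter) and shows that this position can move the number much further than the one earlier step suggested. The change of phenyl for cyclopropyl at the same place gives a 17-fold lower number from compound 1 to compound 3 (1.23 log units; beyond the scatter), so the two carbon substituents are far from interchangeable, and the low number of compound 3 cannot be explained simply as a return from the (6-chlorohexyl)amino group to a carbon substituent on the carbonyl. Compound 3 now holds the lowest number of the three, with both of its steps beyond the scatter, and no measurement available here explains why phenyl stands apart from the other two groups.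

The three compounds leave open whether the low number depends on the six-membered aromatic ring of carbon only or would also be seen with a cyclohexyl ring, a pyridyl ring or a benzyl group. They also leave open how a chlorine or methoxy group on the phenyl ring would shift the number, and whether an unsubstituted hexylamino group would behave like the (6-chlorohexyl)amino group.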